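The compounds below may be only part of what the source reports. "The series", "measured", "known", "first", "only" and "open" are said of these compounds alone.

In a functional assay on NCI-H460 cells (Homo sapiens) for inhibition, read by CCK-8 assay, with a stated time of 72 h, tested at 10 uM (on this read-out higher numbers stand for more inhibition of growth at the one concentration tested and lower numbers for less inhibition of growth), compound 1 (`CN(C)C(=O)c1cc2cnc(Nc3ccc(N)cn3)nc2n1C1CCCC1`) gives 62% and compound 3 (`Nc1ccc(NC(=O)C2(C(=O)Nc3ccc(F)cc3)CC2)cc1F`) gives 62.9% with no gap beyond the scatter. Compound 2 (`CN(C)C(=O)c1cc2cnc(Nc3ccc(NC(=O)C4(C(=O)Nc5ccccc5F)CC4)cc3)nc2n1C1CCCC1`) reaches 93.1% as the highest of the three, beyond the scatter from both others. Compound 4 (`CN(C)C(=O)c1cc2cnc(Nc3ccc(NC(=O)C4(C(=O)Nc5ccccc5)CC4)cc3)nc2n1C1CCCC1`) differs from compound 2 in one place: hydrogen in place of fluoro on an aromatic carbon (2-fluorophenyl to phenyl, ortho to a large group). Among the measured compounds shown here, no measured pair shows this change, so the expectation rests on the single replacement and on compound 2 at 93.1% as the starting point. The estimated a number 3.1 percentage points lower from compound 2 to compound 4 (within the scatter) is small and slightly downward, and it is not expected to go beyond the scatter. For compound 4 the estimate is 90% with an expected range from 76% to 99% in this read-out.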

Compound 4, percent growth inhibition at one concentration: 95.9%
For compound 4 the middle estimate is 5.9 percentage points below the measured one; measured number inside the range.
By their numbers in this assay, from the lowest: compounds 1 and 3 (each within the scatter of the next); then compounds 2 and 4 (each within the scatter of the next).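

In this assay, the step of a number 2.8 percentage points higher from compound 2 to compound 4 (within the scatter) shows that the fluoro on this aromatic carbon, ortho to a large group, can be replaced by hydrogen with no change beyond the scatter. At the one concentration tested, the 2-fluorophenyl and the phenyl therefore cannot be told apart. No supporting data bear on why this replacement leaves the read-out within the scatter. Still open, from the compounds shown here alone, is whether a chloro, methoxy or amine at this position would hold the inhibition. A single concentration also leaves open whether compound 2 and compound 4 would separate at lower concentrations.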